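Removing a Ring Fluorine from a Fused-Core Acid

The source may report more compounds than this note shows. Statements on the series, on what has been measured and on what is new or still open speak of the compounds shown alone.

Compound 1 `Cc1nn(-c2ccccn2)c2cc(-c3ccc(CCC(=O)O)cc3)ccc12` and compound 2 `Cc1nn(-c2ccccn2)c2cc(-c3ccc(CCC(=O)O)cc3F)ccc12` differ only by hydrogen in place of fluoro on an aromatic carbon. In a functional assay on cells for agonist activity at Free fatty acid receptor 1 (Mus musculus), read by FLIPR and calcium flux, with a stated time of 5 min (a higher number here means that more compound is needed for the effect, a lower number that less compound is needed), compound 1 gives 1400 nM. In this assay compound 2 gives 1500 nM. The step of a 1.1-fold lower number from compound 2 to compound 1 (0.03 log units; within the scatter) is within the scatter. Compound 3 `COc1nn(-c2ccccn2)c2cc(-c3ccc([C@H]4C[C@@H]4C(=O)O)cc3)cc(F)c12` has another core; the difference between the two cores is not broken down here. In this assay compound 3 gives > 100000 nM, which is a limit of the assay rather than a number, the limit noted as the limit of > 100000 nM in this assay, at which 1 of the 3 values shown sits.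

Compound 4 `COc1nn(-c2ccccn2)c2cc(-c3ccc([C@H]4C[C@@H]4C(=O)O)cc3)ccc12` differs from compound 3 by hydrogen in place of fluoro on an aromatic carbon. This is the same kind of change as that from compound 2 to compound 1, but at a different place: in compound 2 the fluoro is ortho to a large group and meta to a 2-carboxyethyl group, while in compound 3 it sits on a ring that is part of a fused system, ortho to a fused ring, meta to a fused ring and meta to a large group. Within the data shown here, because compound 3 shows only the limit > 100000 nM, no numerical step to compound 4 can be drawn from it, and the earlier step of a 1.1-fold lower number from compound 2 to compound 1 (0.03 log units; within the scatter) suggests the change itself does little. The step from compound 3 to compound 4 is therefore expected to be about an at least 1.2-fold lower number from compound 3 to compound 4 (0.09 log units; that floor lies within the scatter). Compound 4 is estimated to give 80000 nM in this assay, expected to fall between 10000 nM and 300000 nM.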

Compound 4, half-maximal effective concentration in the Free fatty acid receptor 1 assay: > 100000 nM
Compound 4 gave a limit, no number; the forecaster's own chance of this, stated with the estimate: 50%; at least 1.2-fold (0.09 log units) between middle value and limit.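

In the Free fatty acid receptor 1 assay compound 3 gives > 100000 nM, which is a limit of the assay and not a number. In the Free fatty acid receptor 1 assay compound 4 gives > 100000 nM, which is also a limit of the assay and not a number. The step between them cannot be read: the limit of > 100000 nM in the Free fatty acid receptor 1 assay, at which 2 of the 4 values shown sit.

In a physicochemical assay for lipophilicity, using the shake flask method, measured as octanol-water partition, with a stated time of 30 min, at pH 7.4 (on this read-out lower numbers stand for lower lipophilicity and higher numbers for higher lipophilicity), compound 3 gives 3.8 and compound 4 gives 3.8, which is no change at the digits printed from compound 3 to compound 4 (within the scatter).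

The compounds shown leave open whether exchanging fluoro for hydrogen alters agonist activity on this core.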